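A few compounds are considered here, and "the series" means these few. Any claim that something is new, unique, unknown or untested is made for them only; others in the source may bear on it.

Two members of a common dihydropyridine-type series have been tested in a functional assay (aorta) with Rattus norvegicus as the target; a lower number here means a stronger inhibitor, a higher number a weaker inhibitor. Compound 1 `CCO/C(O)=C1\C(COCCn2cc(N)n(C)c2=O)=NC(C)=C(C(=O)OC)C1c1ccccc1Cl` gives 25.1 nM in this assay. Compound 2 `CCO/C(O)=C1\C(COCCn2cc(C(N)=O)nn2)=NC(C)=C(C(=O)OC)C1c1cccc(Cl)c1Cl`, which carries a different halogen pattern on its phenyl ring and a 4-carbamoyl-1H-1,2,3-triazol-1-yl group on its side chain, gives 3.16 nM, the lower of the two numbers; the gap to compound 1 lies beyond the scatter of repeated measurements. The pair differ in more than one place, so what each change contributes cannot be separated from these two values alone.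

Compound 3 `CCO/C(O)=C1\C(COCCn2ccnn2)=NC(C)=C(C(=O)OC)C1c1cccc(Cl)c1Cl` has not yet been measured in this assay. It differs from compound 2 by a single change, (hydrogen in place of carbamoyl on an aromatic carbon), that is, hydrogen in place of carbamoyl on an aromatic carbon. Going by the values given here, no measured pair shows this exact step, so its size can only be estimated. The carbamoyl adds a hydrogen-bond donor and acceptor that compound 1 lacks in this position, yet compound 1 also differs elsewhere, so no trend can be drawn. A modest loss is expected for compound 3, with a step of a 2.5-fold higher number from compound 2 to compound 3 (0.40 log units; beyond the scatter). Compound 3 is therefore estimated at 8 nM, within a range from 2.5 nM to 25 nM.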

Compound 3, half-maximal inhibitory concentration: 5.01 nM
For compound 3 the middle estimate is 1.6-fold (0.20 log units) above the measured one, and the stated range covers the measured number.
By their numbers in this assay, from the lowest: compounds 2 and 3 (each within the scatter of the next); then compound 1.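

With compound 2 and compound 3, the study has its first pair that differs in one place, and it isolates the carbamoyl on an aromatic carbon of the five-membered aromatic ring with 3 nitrogen. In this assay, the step from the 4-carbamoyl-1H-1,2,3-triazol-1-yl group to the 1H-1,2,3-triazol-1-yl group is a 1.6-fold higher number from compound 2 to compound 3 (0.20 log units; within the scatter), so losing the carbamoyl, with its 3 heavy atoms, hydrogen-bond donor and hydrogen-bond acceptor, leaves no difference that can be told from the scatter, and the low number of compound 2 does not depend on this group. Nothing available explains this result.

The compounds shown do not tell whether other groups on this aromatic carbon, such as an amine, a carboxylic acid or a methyl group, would also stay within the scatter of compound 3. They also leave open what a longer chain in place of the 2-(1H-1,2,3-triazol-1-yl)ethyl group would do, and what the chlorine pattern on the phenyl ring contributes alone.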